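A few compounds are considered here, and "the series" means these few. Any claim that something is new, unique, unknown or untested is made for them only; others in the source may bear on it.

Measured so far in a functional assay on MCF7 cells (Homo sapiens) for inhibition, read by MTT assay, with a stated time of 48 h, tested at 7.5 ug/mL; on this read-out lower numbers stand for less inhibition of growth and higher numbers for more inhibition of growth at the one concentration tested:
- compound 1, `COc1cc2c(c(OC)c1)OCN(c1ccc3oc(-c4ccccc4)cc(=O)c3c1)C2`: 48.9%
- compound 2, `O=c1cc(-c2ccccc2)oc2cc(N3COc4ccccc4C3)ccc12`: 2.65%
- compound 3, `O=c1cc(-c2ccccc2)oc2ccc(N3COc4c(cccc4[N+](=O)[O-])C3)cc12`: 8.2%

Compound 2 holds the lowest of the three numbers in this assay. Its nearest neighbour is compound 3, whose value lies within the scatter of that of compound 2, so no order between those two can be read. Compound 1 stands well apart, its value beyond the scatter above that of compound 2. Among the measured compounds shown here, compounds 1 and 3 differ from compound 2 in more than one place, so no single structural step between measured compounds is available, and nothing here shows what one added substituent on the shared core does.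

Compound 4, `O=c1cc(-c2ccccc2)oc2cc(N3COc4c(Br)cccc4C3)ccc12`, is the next member to be measured. It differs from compound 2 in one place: bromo in place of hydrogen on an aromatic carbon. The bromo enters on an aromatic carbon of a six-membered aromatic ring of carbon only, part of a fused system of two rings, and brings no donor, no acceptor and no charge.

With no measured step of this kind in the series, the expectation is a small step in this assay, if any, in either direction, most likely within the scatter. The estimated step from compound 2 to compound 4 is a number 5.4 percentage points higher from compound 2 to compound 4 (within the scatter). Compound 4 is therefore expected to give about 8%, with a range from 0% to 25%.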

Compound 4, percent growth inhibition at one concentration: 2.21%
The estimate for compound 4 lay 5.8 percentage points above the measured number, and the stated range covers the measured number.
By their numbers in this assay, from the lowest: compounds 4, 2 and 3 (each within the scatter of the next); then compound 1.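

Among the compounds shown here, the step of a number 0.4 percentage points lower from compound 2 to compound 4 (within the scatter) in this assay is the first single-place step, and it comes from bromo in place of hydrogen on an aromatic carbon of a six-membered aromatic ring of carbon only, part of a fused or bridged system of two rings. At this position and at the one concentration tested, the read-out does not separate bromo from hydrogen, so the change shows neither a gain nor a loss of growth inhibition on the shared core. No available measurement bears on the reason for this result.

On these data alone, whether an amine or a carboxylic acid on this same aromatic carbon would give a step beyond the scatter remains open. Also open, as far as these compounds go, is whether bromo on another carbon of this ring would leave the read-out as unchanged as it does here, since this single step speaks for one group at one position only.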